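Amide variation on a thiazolidinedione-benzylidene series

The compounds below may be only part of what the source reports. "The series", "measured", "known", "first", "only" and "open" are said of these compounds alone.

Two members of the series have been run in a functional assay on HepG2 cells (Homo sapiens) for cytotoxicity, read by sulforhodamine B assay, with a stated time of 48 h; on this read-out higher numbers stand for weaker inhibition of growth and lower numbers for stronger inhibition of growth. Compound 1 `Cc1c(NC(=O)COc2ccc(/C=C3\SC(=O)NC3=O)cc2)c(=O)n(-c2ccccc2)n1C` gives only a limit, < 100000 nM. Compound 2 `O=C(COc1ccc(/C=C2\SC(=O)NC2=O)cc1)Nc1nc2ccccc2s1` likewise gives only a limit, < 100000 nM. Among the compounds with values here, both values sit at the same end of the measured range; the only evidence on them is the limit of < 100000 nM in this assay, at which 2 of the 2 values shown sit, so no step between measured compounds can be read. Compound 2 therefore stands nowhere in particular on the numbers shown: its growth inhibition is known only to lie within the assay.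

Compound 3 `O=C(COc1ccc(/C=C2\SC(=O)NC2=O)cc1)Nc1ccccn1` keeps the shared core and carries pyridin-2-yl in place of 1,3-benzothiazol-2-yl on an amide-type nitrogen. Without any measured step to lean on, the step from compound 2 to compound 3 is expected to be none beyond the scatter, and the expected change is a step that the limit leaves unreadable from compound 2 to compound 3. Compound 3 is expected to give about 30000 nM, within a range of 5000 nM to 100000 nM, with a fair chance that this assay again reports only a limit.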

Compound 3, concentration for 50% growth inhibition: < 100000 nM
Compound 3: only a limit was reported; the forecaster's own chance of this, stated with the estimate: 60%; the middle value does not contradict the limit.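

Within the data shown here, compound 2 and compound 3 both give only a limit in this assay, so no step from the pyridin-2-yl change can be read: the limit of < 100000 nM in this assay, at which 3 of the 3 values shown sit. The compounds shown leave open whether these groups on the amide-type nitrogen differ at all in growth inhibition.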